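Working notes: amino in place of hydroxy, compound 4

The compounds below may be only part of what the source reports. "The series", "measured", "known", "first", "only" and "open" are said of these compounds alone.

Measured in a functional assay on SF-295 cells (Homo sapiens) for cytotoxicity, read by sulforhodamine B assay, with a stated time of 48 h; a lower number here means a stronger inhibitor of growth, a higher number a weaker inhibitor of growth:
- compound 1 `COc1cc(C(=O)c2ccc(OC)c(O)c2OC)cc(OC)c1O`: 1400 nM
- compound 2 `COc1ccc(C(=O)c2cc(OC)c(OC)c(OC)c2)c(O)c1O`: 120 nM
- compound 3 `COc1ccc(C(=O)c2cc(OC)c(OC)c(OC)c2)c(OC)c1O`: 19.9 nM

Compound 3 has the lowest number of the three, at 19.9 nM. The gaps to the others are a 6.0-fold lower number from compound 2 to compound 3 (0.78 log units; beyond the scatter) and a 70-fold lower number from compound 1 to compound 3 (1.85 log units; beyond the scatter), both beyond the scatter.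

The next compound is compound 4 `COc1ccc(C(=O)c2cc(OC)c(OC)c(OC)c2)c(OC)c1N`, with amino in place of hydroxy on an aromatic carbon, ortho to two methoxy groups and meta to a large group: amino in place of hydroxy on an aromatic carbon.

Neither measured step is this exchange. Each puts methyl in place of hydrogen on an oxygen on an aromatic ring, so they show only that the series can respond strongly to a change of a single substituent. Going by the values given here, no measured pair gives the size of a swap from hydroxy to amino, and the direction is therefore uncertain. Compound 3 already holds the lowest number, so a small rise in this assay is expected, possibly none beyond the scatter, and the modest step of a 6.0-fold lower number from compound 2 to compound 3 (0.78 log units; beyond the scatter) is taken as a rough outer size. The expected change is a 1.5-fold higher number from compound 3 to compound 4 (0.18 log units; within the scatter). The estimate for compound 4 is 30 nM, with an expected range of 8 nM to 120 nM.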

Compound 4, concentration for 50% growth inhibition: 19.9 nM
Estimate against measurement, compound 4: 1.5-fold (0.18 log units) above; low and high end bracket the measured number.
By their numbers in this assay, from the lowest: compounds 3 and 4 (each within the scatter of the next); then compound 2; then compound 1.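

In this assay, going by these compounds alone, amino in place of hydroxy on this aromatic carbon gives no change at the digits printed from compound 3 to compound 4 (within the scatter) and is the first reading of this exchange. The earlier steps shown here, such as a 70-fold lower number from compound 1 to compound 3 (1.85 log units; beyond the scatter) and a 6.0-fold lower number from compound 2 to compound 3 (0.78 log units; beyond the scatter) in the same assay, showed only that methyl in place of hydrogen on an oxygen can matter strongly; this result shows that at the position ortho to two methoxy groups and meta to a large group, the hydroxy oxygen is not needed to keep the number at the level of compound 3. No measured property of either group is available to account for this result.

The compounds shown leave open how far this position accepts other groups, for instance an acetamide or a dimethylamino group in place of the amino, or a bare hydrogen in place of any substituent. They also leave open whether amino in place of hydroxy reads the same way at other positions on the core or in cells other than those of this assay in this series.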